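Swapping the Amide Substituent: Benzyl to Cyclohexyl

A few compounds are considered here, and "the series" means these few. Any claim that something is new, unique, unknown or untested is made for them only; others in the source may bear on it.

Measured compounds:
- compound 1 `N[C@H]1CC[C@H](Nc2c(C(=O)NCc3ccc(Cl)cc3Cl)nc(Br)c3cccnc23)CC1`: "not determined" (no result reported) in a functional assay on MCF7 cells (Homo sapiens) for cytotoxicity, read by MTT assay, with a stated time of 72 h; on this read-out lower numbers stand for stronger inhibition and higher numbers for weaker inhibition
- compound 2 `N[C@H]1CC[C@H](Nc2c(C(=O)NCc3ccc(F)cc3)nc(Br)c3cccnc23)CC1`: 2000 nM in this assay
- compound 3 `C[C@H](Nc1c(C(=O)NCc2ccc(F)cc2)nc(Br)c2cccnc12)c1ccccc1`: "not determined" (no result reported) in this assay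

For the measured compounds named here, compound 2 is the only member of this small group with a number in this assay, where compound 2 gives 2000 nM. Compound 1 and compound 3 share the brominated core and the amide, but for compound 1 the entry reads "not determined" (no result reported) and for compound 3 it reads "not determined" (no result reported), so nothing can be said about how they compare with compound 2.

Compound 4 `N[C@H]1CC[C@H](Nc2c(C(=O)NC3CCCCC3)nc(Br)c3cccnc23)CC1` has not yet been measured in this assay. It differs from compound 2 in one place: cyclohexyl in place of 4-fluorobenzyl on an amide-type nitrogen. Going by the values given here, no pair of measured compounds shows what this kind of exchange does on this series, so the expectation rests on compound 2 alone and on the nature of the change, an aromatic ring giving way to a non-aromatic one of the same size.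

Compound 4 is therefore expected to stay close to compound 2, with a step of a 1.5-fold higher number from compound 2 to compound 4 (0.18 log units; within the scatter) that is estimated to lie around the edge of the usual scatter, leaning towards weaker inhibition. The value for compound 4 is expected to be 3000 nM, within a range from 1000 nM to 10000 nM.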

Compound 4, half-maximal inhibitory concentration: 5200 nM
Compound 4: middle estimate off by 1.7-fold (0.24 log units), on the low side; low and high end bracket the measured number.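

In this assay, for the compounds shown here, cyclohexyl in place of 4-fluorobenzyl on the amide-type nitrogen gives a 2.6-fold higher number from compound 2 to compound 4 (0.41 log units; beyond the scatter), a modest step but one beyond the usual scatter, and this is the first sign that the group at this place affects the read-out, with weaker inhibition for the non-aromatic ring. The exchange changes several things at once, since the aromatic ring and the fluorine both leave and the group entering has fewer heavy atoms, so this single step cannot assign the shift to any one of them. No measurement at hand offers a reason for the step.

The compounds shown leave open whether a plain benzyl, with the fluorine gone but the aromatic ring kept, would fall with compound 2 or with compound 4, and the same question applies to a cyclohexylmethyl group, which keeps the non-aromatic ring on a one-carbon link. They also leave open whether an amine or a carboxylic acid on this ring, or a longer chain on the same nitrogen, would move the number in either direction.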